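The compounds below may be only part of what the source reports. "The series", "measured", "known", "first", "only" and "open" are said of these compounds alone.

Measured compounds in a functional assay on CHO cells for agonist activity at prostaglandin E2 receptor EP1 subtype (Homo sapiens), read by fluorescence and calcium flux; on this read-out higher numbers stand for an effect only at larger amounts of compound and lower numbers for an effect already at smaller amounts:
- compound 1 `O=C(O)c1csc([C@H]2CC[C@@H]3[C@@H](/C=C/COc4ccccc4)[C@H](O)C[C@@H]3O2)n1`: 700 nM
- compound 2 `O=C(O)c1csc([C@H]2CC[C@@H]3[C@@H](COc4ccccc4)[C@H](O)C[C@@H]3O2)n1`: > 10000 nM (limit)
- compound 3 `O=C(O)c1csc([C@H]2CC[C@@H]3[C@@H](CCCCCOc4ccccc4)[C@H](O)C[C@@H]3O2)n1`: "not determined" (no result reported)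

Compound 1 carries a phenoxy group on an unsaturated three-carbon chain and in this assay compound 1 gives 700 nM. Compound 2, with the phenoxy group on a single chain carbon, gives only a limit of the assay in this assay, > 10000 nM. That limit is the one described as the limit of > 10000 nM in this assay, at which 1 of the 3 values shown sits. Compound 3, with the phenoxy group on a saturated five-carbon chain, has no number in this assay; it stands outside the measured pair, so nothing about the length of its chain can be read off.

Compound 4 `O=C(O)c1csc([C@H]2CC[C@@H]3[C@@H](CCOc4ccccc4)[C@H](O)C[C@@H]3O2)n1` is the next member: phenoxy in place of 3-phenoxypropyl on a saturated chain carbon, two bonds along the chain from a saturated ring carbon. No step between measured compounds carries a number, so the size expected for compound 4 rests on the two shown values alone. Compound 4 sits, by chain length, between compound 2 and compound 1, and a value in between those two is the working expectation, with the limit of the assay a real possibility.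

Compound 4 is expected to give about 3000 nM in this assay, with a range from 700 nM to 20000 nM.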

Compound 4, half-maximal effective concentration: 97 nM
Compound 4: the middle estimate sits 31-fold (1.49 log units) above what was measured, outside the stated range (below it).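

At this place on the shared core, chain length alone carries a large change in this assay: moving from phenoxy on a single chain carbon to phenoxy on a longer saturated chain gives an at least 100-fold lower number from compound 2 to compound 4 (2.01 log units; beyond the scatter). The value of compound 2 is a limit of the assay and not a number, so the true size of this step stays unknown: the limit of > 10000 nM in this assay, at which 1 of the 4 values shown sits.
With a fully saturated chain, compound 4 gives 97 nM, which shows that a double bond in the chain, as carried by compound 1, is not required for a measurable response on this read-out.

Compound 3 carries no number and its step to compound 4 cannot be read, leaving open how a saturated chain longer than that of compound 4 behaves in this assay. Also open, going by these compounds, is whether the response survives an amine in place of the chain oxygen, or a fluorine or a methoxy group on the phenyl ring of compound 4.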